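Cytotoxicity notes: aryl swap on the exocyclic alkene

A few compounds are considered here, and "the series" means these few. Any claim that something is new, unique, unknown or untested is made for them only; others in the source may bear on it.

Compound 3 `COc1ccc(/C=C2\C(=O)N(c3c(Cl)cccc3Cl)c3ccccc32)cc1` has been measured in a functional assay on L132 cells (Homo sapiens) for cytotoxicity, read by MTT assay, with a stated time of 72 h; on this read-out lower numbers stand for an effect already at smaller amounts and higher numbers for an effect only at larger amounts of compound. In this assay compound 3 gives > 100 ug/mL, which is a limit of the assay and not a number. Compound 1 `COc1ccc(/C=C2\C(=O)N(c3c(Cl)cccc3Cl)c3ccccc32)cc1OC` gives > 100 ug/mL, also a limit. Compound 2 `O=C1/C(=C\c2ccc(O)cc2)c2ccccc2N1c1c(Cl)cccc1Cl` gives 30 ug/mL. The step that the two limits leave unreadable from compound 1 to compound 3 cannot be read; the step of an at least 3.3-fold higher number from compound 2 to compound 3 (0.52 log units; beyond the scatter) is at least modest. Compound 3 thus sits at the limit of > 100 ug/mL in this assay, at which 2 of the 3 values shown sit. Compound 4 `O=C1/C(=C\c2ccccc2Cl)c2ccccc2N1c1c(Cl)cccc1Cl` differs by 2-chlorophenyl in place of 4-methoxyphenyl on a double-bonded chain carbon bound to a double-bonded ring carbon. Both measured steps keep an oxygen on that ring; neither bears directly on this change. Compound 4 is therefore expected to stay near the limit, with the step of a number no higher from compound 3 to compound 4 (the limit leaves the size open) expected to lie within the scatter, giving an estimated 100 ug/mL (range 35 ug/mL to 300 ug/mL).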

Compound 4, concentration for half-maximal effect: > 100 ug/mL
Compound 4 ended at the assay's limit (the forecaster's own chance of this, stated with the estimate: 65%); the middle value sits exactly at the limit.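

In this assay, 2-chlorophenyl at this place keeps compound 4 at a limit of the assay and not at a number, so no oxygen on this ring is needed for that outcome. Set against 4-hydroxyphenyl, the same group gives an at least 3.3-fold higher number from compound 2 to compound 4 (0.52 log units; beyond the scatter). Compound 2 remains the only compound shown with a number, and the steps among the limit compounds cannot be read: the limit of > 100 ug/mL in this assay, at which 3 of the 4 values shown sit.

On these data alone, how far compound 1, compound 3 and compound 4 lie beyond the limit stays open. Also open, as far as these compounds go, is whether an amine or a carboxylic acid on this ring would give a number like that of compound 2.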